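Methyl to fluoro on a benzyl group

The compounds below may be only part of what the source reports. "The series", "measured", "known", "first", "only" and "open" are said of these compounds alone.

In a functional assay on HepG2 cells (Homo sapiens) for inhibition, read by MTT assay, with a stated time of 72 h (on this read-out higher numbers stand for weaker inhibition and lower numbers for stronger inhibition), compound 1 `O=C1/C(=C\c2ccccc2)c2c(ncn2COCc2ccccc2)CCN1Cc1ccccc1` gives 13900 nM. Compound 2 `Cc1ccc(CN2CCc3ncn(COCc4ccccc4)c3/C(=C/c3ccccc3)C2=O)cc1` differs only by a methyl in place of hydrogen on an aromatic carbon, and compound 2 gives 44700 nM. This is the higher of the two numbers, which makes compound 2 the weaker inhibitor of the pair.

Compound 3 `O=C1/C(=C\c2ccccc2)c2c(ncn2COCc2ccccc2)CCN1Cc1ccc(F)cc1` keeps the shared core and changes one place: fluoro in place of methyl on an aromatic carbon. Here, fluoro takes the place of methyl on an aromatic carbon, so 4-methylbenzyl becomes 4-fluorobenzyl.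

Within the data shown here, only one measured step bears on this change: a 3.2-fold higher number from compound 1 to compound 2 (0.51 log units; beyond the scatter). That modest rise came with the methyl arriving on the same aromatic carbon. Removing the methyl may therefore undo much of the rise, if fluoro behaves more like hydrogen than like methyl. Among the measured compounds shown here, no fluoro compound has been measured yet, so this remains a loose guide. The expected change is a 2.0-fold lower number from compound 2 to compound 3 (0.31 log units; beyond the scatter), towards stronger inhibition. For compound 3, the estimated value is 22000 nM, with an expected range from 8000 nM to 55000 nM.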

Compound 3, half-maximal inhibitory concentration: 39400 nM
The estimate for compound 3 lay 1.8-fold (0.25 log units) below the measured number, and the stated range covers the measured number.
By their numbers in this assay, from the lowest: compound 1; then compounds 3 and 2 (each within the scatter of the next).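

Fluoro in place of methyl on this aromatic carbon gives a 1.1-fold lower number from compound 2 to compound 3 (0.05 log units; within the scatter), so the two groups cannot be told apart at this position in this assay. Fluoro in place of hydrogen gives a 2.8-fold higher number from compound 1 to compound 3 (0.45 log units; beyond the scatter), and methyl in place of hydrogen gives a 3.2-fold higher number from compound 1 to compound 2 (0.51 log units; beyond the scatter), which shows that the rise in the number is not specific to methyl: among these three compounds, the unsubstituted benzyl group gives the lowest number, and both para groups move away from it. Nothing measured on these compounds explains this shared rise.

Still open, as far as these compounds go, is whether any group at this place, para to a large group, can bring the number below that of compound 1, and a methoxy group, an amine or a carboxylic acid on the same aromatic carbon would put this to the test. From the compounds shown here alone, it is also open whether fluoro and methyl would match each other on a different carbon of this ring, or whether a longer chain in place of the benzyl group would change the picture.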